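The compounds below may be only part of what the source reports. "The series", "measured", "known", "first", "only" and "open" are said of these compounds alone.

- Compound 1 `CCOC(=O)/C=C/c1ccc2c(c1)C(=O)C(=O)N2Cc1ccc(OC)cc1` gives 60 nM
- Compound 2 `CC(C)(C)OC(=O)/C=C/c1ccc2c(c1)C(=O)C(=O)N2Cc1ccc(Br)cc1` gives 730 nM
- Compound 3 `COC(=O)/C=C/c1ccc2c(c1)C(=O)C(=O)N2Cc1ccc(C#N)cc1` gives 50 nM

In a functional assay on HT-29 cells (Homo sapiens) for cytotoxicity, read by MTT assay, with a stated time of 48 h (a lower number here means a stronger inhibitor, a higher number a weaker inhibitor), compound 1 stands second highest of the three numbers. Its number lies within the scatter of that of compound 3, while compound 2 sits higher, beyond the scatter.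

Compound 4 `COc1ccc(CN2C(=O)C(=O)c3cc(/C=C/C(=O)N4CCCC4)ccc32)cc1` is not yet measured. It keeps the core of compound 1, with pyrrolidin-1-yl in place of ethoxy on a carbonyl carbon. Within the data shown here, no measured pair shows this change, so the expectation is loose. Among the measured compounds shown here, compound 2 at 730 nM shows only that numbers in this set can rise well above that of compound 1. In this assay a move to a higher number, meaning a weaker inhibitor, is expected, beyond the scatter. The estimated change is a 6.7-fold higher number from compound 1 to compound 4 (0.82 log units; beyond the scatter) in size. Compound 4 is estimated at 400 nM (expected range 80 nM to 2500 nM).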

Compound 4, half-maximal inhibitory concentration: 5230 nM
Compound 4: middle estimate off by 13-fold (1.12 log units), on the low side; the whole stated range lies below it.
By their numbers in this assay, from the lowest: compounds 3 and 1 (each within the scatter of the next); then compound 2; then compound 4.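

In this assay, putting pyrrolidin-1-yl in place of ethoxy on a carbonyl carbon gives an 87-fold higher number from compound 1 to compound 4 (1.94 log units; beyond the scatter), so the group on this carbonyl strongly affects the result. This is the only pair shown that differs in one place, which allows this change to be read on its own. No measurement shown explains the loss.

As far as these compounds go, it remains open whether the ring or the nitrogen link matters more. An open-chain diethylamino group, a piperidin-1-yl ring or a free carboxylic acid at this carbonyl would help separate these possibilities.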